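A Second Methoxy Step Weighed Against the First

A few compounds are considered here, and "the series" means these few. Any claim that something is new, unique, unknown or untested is made for them only; others in the source may bear on it.

Measured in a functional assay on HCT-116 cells (Homo sapiens) for antiproliferative activity, read by MTT assay, with a stated time of 72 h; a lower number here means a stronger inhibitor, a higher number a weaker inhibitor:
Compound 1 `O=C(CCc1cccc2c1B(O)OC2)Nc1ccccc1` gives 350 nM
Compound 2 `COc1ccc(NC(=O)CCc2cccc3c2B(O)OC3)cc1` gives 1700 nM
Compound 3 `COc1cccc(-c2cccc(NC(=O)CCc3ccc4c(c3)B(O)OC4)c2)c1` gives 21000 nM

Compound 2 differs from compound 1 by methoxy in place of hydrogen on an aromatic carbon, and that change gave a 4.9-fold higher number from compound 1 to compound 2 (0.69 log units; beyond the scatter). Compound 3 stands on a different core; how its core differs from that of compound 1 is not broken down here, and its number is the highest of the three.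

Compound 4 `COc1cc(OC)cc(-c2cccc(NC(=O)CCc3ccc4c(c3)B(O)OC4)c2)c1` is not yet measured. It differs from compound 3 by methoxy in place of hydrogen on an aromatic carbon. This is the same kind of change as from compound 1 to compound 2, though the place differs: in compound 2 the methoxy sits para to a large group, whereas in compound 4 it sits meta to a large group and meta to a methoxy group. Because of a 4.9-fold higher number from compound 1 to compound 2 (0.69 log units; beyond the scatter), for compound 4 the expected step is a 2.1-fold higher number from compound 3 to compound 4 (0.33 log units; beyond the scatter), resting on that single earlier step alone. Compound 4 is therefore estimated at 45000 nM, between 15000 nM and 130000 nM.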

Compound 4, half-maximal inhibitory concentration: 3700 nM
Estimate against measurement, compound 4: 12-fold (1.09 log units) above, and the stated range ends above it.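

The change from 3-methoxyphenyl to 3,5-dimethoxyphenyl gave a 5.7-fold lower number from compound 3 to compound 4 (0.75 log units; beyond the scatter). Set beside the earlier methoxy step, this runs the opposite way: the same change on two cores in this assay, a 4.9-fold higher number (0.69 log units; beyond the scatter) from compound 1 to compound 2 and a 5.7-fold lower number (0.75 log units; beyond the scatter) from compound 3 to compound 4, 28-fold (1.44 log units) apart, beyond the scatter of two such steps. Going by these compounds alone, a methoxy step read on one core therefore cannot be carried over to the other, although this rests on only two pairs. The result does not show whether the reversal follows from the core, from the place of the new methoxy, or from the methoxy already present in compound 3, as the two steps differ in all of these at once.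

The compounds shown leave open how a methoxy at one matching place would act on both cores. They also leave open whether an amine or a fluorine at that place would follow the same course.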